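The source may report more compounds than this note shows. Statements on the series, on what has been measured and on what is new or still open speak of the compounds shown alone.

Working notes on the series. The shared core is an enone carrying a pyrazole that bears a phenyl and a pyridinyl; the variable part is the aryl group on the carbonyl carbon. Compound 1 `O=C(/C=C/c1cn(-c2ccccc2)nc1-c1cccnc1)c1ccsc1` carries a thiophen-3-yl there and in a functional assay on HCT-116 cells (Homo sapiens) for inhibition, read by sulforhodamine B assay, with a stated time of 72 h (a higher number here means a weaker inhibitor, a lower number a stronger inhibitor), compound 1 gives 1300 nM. Compound 2 `O=C(/C=C/c1cn(-c2ccccc2)nc1-c1cccnc1)c1ccccn1` carries a pyridin-2-yl instead, and in this assay compound 2 gives 2100 nM. The step of a 1.6-fold higher number from compound 1 to compound 2 (0.21 log units; within the scatter) is the only measured comparison so far, and it separates the two compounds by nothing beyond the scatter, so compound 2 and compound 1 stand together on the numbers shown.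

Compound 3 `O=C(/C=C/c1cn(-c2ccccc2)nc1-c1cccnc1)c1cc[nH]c1` continues the exchange of the aryl group on the carbonyl carbon: 1H-pyrrol-3-yl in place of pyridin-2-yl on a carbonyl carbon. Among the compounds with values here, the one step that bears on this position, the exchange from compound 1 to compound 2, stayed within the scatter, and nothing in the measured data points to a direction for a further aryl exchange at this place. The expected step is therefore a 1.2-fold lower number from compound 2 to compound 3 (0.07 log units; within the scatter), none beyond the scatter. In this assay compound 3 is estimated at 1800 nM, with a range from 700 nM to 4500 nM.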

Compound 3, half-maximal inhibitory concentration: 7400 nM
For compound 3 the middle estimate is 4.1-fold (0.61 log units) below the measured one; measured number above the stated range.
By their numbers in this assay, from the lowest: compounds 1 and 2 (each within the scatter of the next); then compound 3.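

Within the data shown here, the aryl group on the carbonyl carbon is not indifferent to exchange: in this assay, 1H-pyrrol-3-yl gives a 3.5-fold higher number from compound 2 to compound 3 (0.55 log units; beyond the scatter) and a 5.7-fold higher number from compound 1 to compound 3 (0.76 log units; beyond the scatter), whereas the only earlier step at this place, a 1.6-fold higher number from compound 1 to compound 2 (0.21 log units; within the scatter), gave no separation. Ring size alone does not sort the three compounds, since the five-membered thiophen-3-yl of compound 1 stands with the six-membered pyridin-2-yl of compound 2, while the five-membered 1H-pyrrol-3-yl of compound 3 stands apart, and the hydrogen-bond donor of 1H-pyrrol-3-yl is the feature that neither of the other two groups shares. That association is only a count read from the structures, and no measurement is available that explains the weaker number of compound 3.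

The compounds shown leave open whether the weaker number goes with the ring hydrogen or with the pyrrole ring as such, a distinction that a 1-methyl-1H-pyrrol-3-yl group on the carbonyl carbon would address. They also leave open how a plain phenyl, or an aryl group bearing an amine or a carboxylic acid, would stand at this place.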